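The source may hold more compounds than are shown below. What is called first, only, known or untested is meant among the compounds shown, and "the series" means these compounds.

Working notes on the series in an assay on HEK293 cells for displacement of a labelled ligand from NPC1-like intracellular cholesterol transporter 1 (Homo sapiens); on this read-out higher numbers stand for weaker inhibition and lower numbers for stronger inhibition.

Of the compounds shown here, three have been measured. Compound 1 `CC(C)(C)c1ccc(C(=O)N2CCC3(CC2)C(=O)N(CC(=O)N2CCC(CCO)CC2)CN3c2ccccc2)cc1` gives 2600 nM in this assay. Compound 2 `CC(C)(C)c1ccc(C(=O)N2CCC3(CC2)C(=O)N(CC(=O)NCCCCCNS(C)(=O)=O)CN3c2ccccc2)cc1` gives 5500 nM. Compound 3 `CC(C)(C)OC(=O)NCC1CCCN(C(=O)CN2CN(c3ccccc3)C3(CCN(C(=O)c4ccc(C(C)(C)C)cc4)CC3)C2=O)C1` gives 9500 nM. Going by the values given here, the one step that can be read directly is a 2.1-fold higher number from compound 1 to compound 2 (0.33 log units; beyond the scatter). Compound 2 thus stands second highest of the three numbers: the gap to compound 3 is within the scatter, while the gap to compound 1 lies beyond it.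

Compound 4 `CC(C)(C)c1ccc(C(=O)N2CCC3(CC2)C(=O)N(CC(=O)NCCCCCO)CN3c2ccccc2)cc1` differs from compound 2 in one place: hydroxy in place of methanesulfonamido on a saturated chain carbon, five bonds along the chain from an amide-type nitrogen. Among the compounds with values here, no measured pair isolates this particular exchange. Within the data shown here, the only step that touches the same region of the molecule is a 2.1-fold higher number from compound 1 to compound 2 (0.33 log units; beyond the scatter), in which a chain ending in a hydroxy-bearing group gives way to the chain carrying methanesulfonamido, yet that step also alters the amide substituent itself, so it carries only indirect weight here. Returning to a terminal hydroxy is therefore expected to move the number back toward that of compound 1, though not necessarily by the full amount. The estimated step is a 1.4-fold lower number from compound 2 to compound 4 (0.14 log units; within the scatter). Compound 4 is expected to give about 4000 nM in this assay, within a range of 1500 nM to 11000 nM.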

Compound 4, half-maximal inhibitory concentration: 9400 nM
Beside the measured number, compound 4's estimate is 2.4-fold (0.37 log units) below it, and the stated range covers the measured number.
By their numbers in this assay, from the lowest: compound 1; then compounds 2, 4 and 3 (each within the scatter of the next).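

On the five-carbon chain, in this assay, hydroxy in place of methanesulfonamido gives a 1.7-fold higher number from compound 2 to compound 4 (0.23 log units; within the scatter), so this exchange of the terminal group, five bonds along the chain from an amide-type nitrogen, does not separate the two compounds. The other new step, a 3.6-fold higher number from compound 1 to compound 4 (0.56 log units; beyond the scatter), is beyond the scatter and has a hydroxy-bearing group on both sides, so (5-hydroxypentyl)amino in place of 4-(2-hydroxyethyl)piperidin-1-yl is read here with a terminal hydroxy present in both compounds. Set beside a 2.1-fold higher number from compound 1 to compound 2 (0.33 log units; beyond the scatter), it shows that compound 2 and compound 4 both give higher numbers than compound 1, whichever of the two terminal groups the chain carries, and no measurement available here bears on the reason for either step.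

Going by these compounds, whether a terminal amine or carboxylic acid on the same chain would also stay within the scatter of hydroxy and methanesulfonamido remains open. Also open, on these data alone, is whether a shorter or longer chain carrying the terminal hydroxy would bring the number closer to that of compound 1, or whether the same holds with 4-(2-hydroxyethyl)piperidin-1-yl replaced by an acyclic tertiary amide.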